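This account rests on a few compounds, and the source may have more. Where it says the series, first, only, none or still open, it means among the compounds named here.

The study measured antiproliferative activity in a functional assay on HepG2 cells (Homo sapiens) for antiproliferative activity, read by MTT assay, with a stated time of 72 h; on this read-out higher numbers stand for weaker inhibition and lower numbers for stronger inhibition. Compound 1 `O=C1O/C(=C\Cn2cc(-c3ccc(Br)cc3)nn2)C(OCc2ccccc2)=C1OCc1ccccc1` carries a 4-bromophenyl group on the shared core. In this assay compound 1 returns only a limit of the assay, > 100000 nM, not a number, and this is the limit of > 100000 nM in this assay, at which 1 of the 3 values shown sits. Two related compounds were measured as numbers. Compound 2 `CCCCCc1ccc(-c2cn(C[C@H](O)[C@H]3OC(=O)C(OCc4ccccc4)=C3OCc3ccccc3)nn2)cc1` gives 7460 nM in this assay. Compound 3 `O=C1O[C@H]([C@@H](O)Cn2cc(-c3cc(F)cc(F)c3)nn2)C(OCc2ccccc2)=C1OCc1ccccc1` gives 11600 nM in this assay. For the measured compounds named here, the one single-point step among the measured compounds, a 1.6-fold higher number from compound 2 to compound 3 (0.19 log units; within the scatter), exchanges one aryl group for another and lies within the scatter.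

Compound 4 `O=C1O/C(=C\Cn2cc(-c3cccc(O)c3)nn2)C(OCc2ccccc2)=C1OCc1ccccc1` differs from compound 1 by 3-hydroxyphenyl in place of 4-bromophenyl on an aromatic carbon. Going by the values given here, the only measured step that bears on this change is the aryl exchange from compound 2 to compound 3, and that step was within the scatter; compound 1 itself sits at the limit, where a change of that size could not be read in any case. The expected step, a number no higher from compound 1 to compound 4 (the limit leaves the size open), is therefore none beyond the scatter, with a fair chance that compound 4 also returns only the limit in this assay. Compound 4 is estimated at 100000 nM, with a range from 30000 nM to 300000 nM.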

Compound 4, half-maximal inhibitory concentration: 61700 nM
Compound 4: the middle estimate sits 1.6-fold (0.21 log units) above what was measured; low and high end bracket the measured number.
By their numbers in this assay, from the lowest: compounds 2 and 3 (each within the scatter of the next); then compound 4. At a limit, above all of these: compound 1.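

In this assay, 3-hydroxyphenyl in place of 4-bromophenyl on this aromatic carbon of the five-membered ring gives an at least 1.6-fold lower number from compound 1 to compound 4 (0.20 log units; that floor lies within the scatter). With this change, the core of compound 1 yields a readable number rather than only a limit, so a change at this position can now be followed on that core, which compound 1 alone could not show. Whether the true step goes beyond the scatter remains unsettled because compound 1 returns only a limit: the limit of > 100000 nM in this assay, at which 1 of the 4 values shown sits.

The compounds shown do not separate the effect of adding the hydroxyl group from that of removing the bromine, or from that of moving the substituent to a different place on the phenyl ring, and an unsubstituted phenyl or a 4-hydroxyphenyl group on this carbon would help to tell these apart. They also leave open how a methoxyphenyl or an aminophenyl group at this position would read in this assay, and whether either would give a number or only a limit.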